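The source may hold more compounds than are shown below. What is called first, only, known or untested is meant among the compounds shown, and "the series" means these compounds.

Measured compounds:
compound 1 `O=C(CN1CCC(Cc2ccccc2)CC1)Nc1ccc(C(=O)/C=C/c2cn(Cc3ccc(Br)cc3)nn2)cc1`, a functional assay on SK-N-SH cells (Homo sapiens) for inhibition, read by MTT assay; a lower number here means a stronger inhibitor, a higher number a weaker inhibitor: 42900 nM
compound 2 `COc1ccccc1N1CCN(CC(=O)Nc2ccc(C(=O)/C=C/c3cn(Cc4ccc(Br)cc4)nn3)cc2)CC1`, this assay: 28000 nM

Among the measured compounds shown here, only two compounds have numbers. In this assay compound 1 gives 42900 nM, and compound 2 gives 28000 nM; the two values lie within the scatter of each other, so neither can be set above the other, and both are weak inhibitors. No step between measured compounds that differ in one place is shown.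

Compound 3 `CCCCCCCCCCn1cc(/C=C/C(=O)c2ccc(NC(=O)CN3CCC(Cc4ccccc4)CC3)cc2)nn1` has not been measured. It differs from compound 1 by nonyl in place of 4-bromophenyl on a saturated chain carbon bound to an aromatic nitrogen. Nothing measured here speaks to such a change, so the expected step of a 1.2-fold lower number from compound 1 to compound 3 (0.09 log units; within the scatter) is taken as none beyond the scatter, with a wide uncertainty in either direction. The estimate for compound 3 in this assay is 35000 nM, expected to fall between 10000 nM and 120000 nM.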

Compound 3, half-maximal inhibitory concentration: 33300 nM
Beside the measured number, compound 3's estimate is 1.1-fold (0.02 log units) above it; the measured number falls inside the stated range.
By their numbers in this assay, from the lowest: compounds 2, 3 and 1 (each within the scatter of the next).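

Among the compounds shown here, this is the first step that can be read at this position, a saturated chain carbon bound to an aromatic nitrogen: in this assay nonyl in place of 4-bromophenyl gives a 1.3-fold lower number from compound 1 to compound 3 (0.11 log units; within the scatter) and so stays within the scatter. An open chain can therefore stand where the bromine-bearing aromatic ring stood with no difference this read-out can tell, and on the core of compound 1 that ring is not shown to be needed for the weak inhibition seen. No measurement shown bears on why the two groups read alike.

From the compounds shown here alone, whether a much shorter chain, or a chain ending in an amine or a carboxylic acid, would move the number beyond the scatter at this place stays open. So does whether the same exchange would read alike on the core of compound 2.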